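The source may hold more compounds than are shown below. What is called first, only, known or untested is meant among the compounds shown, and "the series" means these compounds.

Compounds measured so far:
- compound 1, `Cc1ccc(NC(=S)NC(=O)c2ccc(OCc3ccc(Cl)c(Cl)c3)cc2)cc1-c1nc2ccccc2[nH]1` — 6390 nM
- compound 2, `Cc1ccc(NC(=O)NC(=O)c2ccc(OCc3ccc(C(F)(F)F)cc3)cc2)cc1-c1nc2ccccc2[nH]1` — 14900 nM

In a functional assay on MGC-803 cells (Homo sapiens) for inhibition, read by MTT assay, with a stated time of 48 h (on this read-out lower numbers stand for stronger inhibition and higher numbers for weaker inhibition), compound 2 gives the highest of the two numbers; compound 1 gives the lower number, and the gap between them lies beyond the usual scatter. Compound 1 and compound 2 differ in two places at once, so their gap cannot be tied to a single change.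

Compound 3, `Cc1ccc(NC(=O)NC(=O)c2ccc(OCc3ccc(Cl)c(Cl)c3)cc2)cc1-c1nc2ccccc2[nH]1`, has not been measured in this assay. It is built from compound 2 by one change: 3,4-dichlorophenyl in place of 4-(trifluoromethyl)phenyl on a saturated chain carbon bound to an oxygen on an aromatic ring. The ring that enters is the same ring that compound 1 carries at that place, while the rest of compound 3 matches compound 2.

Among the measured compounds shown here, no measured pair isolates this change, so the size of its step rests on little. A step toward a lower number is expected from compound 2 to compound 3, a 1.6-fold lower number from compound 2 to compound 3 (0.20 log units; within the scatter), though it may well stay within the scatter. Compound 3 is therefore estimated at 9500 nM in this assay, with a range from 4000 nM to 22000 nM.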

Compound 3, half-maximal inhibitory concentration: 6080 nM
For compound 3 the middle estimate is 1.6-fold (0.19 log units) above the measured one; measured number inside the range.
By their numbers in this assay, from the lowest: compounds 3 and 1 (each within the scatter of the next); then compound 2.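

In this assay, putting 3,4-dichlorophenyl in place of 4-(trifluoromethyl)phenyl on a saturated chain carbon bound to an oxygen on an aromatic ring gives a 2.5-fold lower number from compound 2 to compound 3 (0.39 log units; beyond the scatter), the first view of this ring change with the rest of the molecule held constant, and it shows that the choice of ring at this place can shift the number, though modestly. Compound 3 also differs from compound 1 in one place, an oxygen where compound 1 has a sulfur in the link, and compound 1 at 6390 nM and compound 3 at 6080 nM lie within the usual scatter of each other, so this pair shows no readable effect of that swap. Nothing available explains why the ring change shifts the number.

The compounds shown leave open whether the dichloro pattern itself matters, since a plain phenyl ring, a ring with a single chlorine or a ring bearing an amine could each give a different number at this place. Also open, on these data alone, is whether the sulfur link would remain without a readable effect when paired with 4-(trifluoromethyl)phenyl.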